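Swapping Trifluoromethyl for Fluoro on an Aromatic Carbon

The source may hold more compounds than are shown below. What is called first, only, known or untested is meant among the compounds shown, and "the series" means these compounds.

Compound 1 `O=C1OC[C@H](Cc2ccccc2)[C@H]1Cc1ccccc1O` gives 83000 nM
Compound 2 `O=C1OC[C@H](Cc2ccccc2)[C@H]1Cc1cccc(C(F)(F)F)c1` gives 34000 nM

Both compounds were tested in a functional assay on HL-60 cells (Homo sapiens) for cytotoxicity, read by WST assay, with a stated time of 48 h; a lower number here means that less compound is needed, a higher number that more compound is needed for the effect. Compound 2 holds the lower of the two numbers, so less of it is needed for the effect. The gap to compound 1 is larger than the usual scatter of repeat measurements, although both values remain high on the scale.

The next compound to be tested is compound 3 `O=C1OC[C@H](Cc2ccccc2)[C@H]1Cc1cccc(F)c1`. It keeps the shared core of compound 2 and carries fluoro in place of trifluoromethyl on an aromatic carbon, a swap that leaves the rest of the structure untouched (fluoro in place of trifluoromethyl on an aromatic carbon).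

Among the compounds with values here, no pair of measured compounds shows what a single such swap does, so any forecast is uncertain. The two known results lie fairly close together, with compound 1 at 83000 nM and compound 2 at 34000 nM, which suggests only a modest shift. The expected change is a 1.5-fold higher number from compound 2 to compound 3 (0.17 log units; within the scatter), a small move toward a higher number that stays within the scatter. For compound 3 the estimated value is 50000 nM, with an expected range from 24000 nM to 100000 nM.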

Compound 3, half-maximal effective concentration: 75000 nM
Beside the measured number, compound 3's estimate is 1.5-fold (0.18 log units) below it; the measured number falls inside the stated range.
By their numbers in this assay, from the lowest: compound 2; then compounds 3 and 1 (each within the scatter of the next).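

In this assay, the trifluoromethyl group on this aromatic carbon now has a direct single-change comparison: putting fluoro in its place, with 1 heavy atom instead of 4, gives a modest rise that lies beyond the scatter (a 2.2-fold higher number from compound 2 to compound 3 (0.34 log units; beyond the scatter)). So at this position the choice between these two groups makes a readable difference, even though all three numbers remain high on the scale. The other step, with 3-fluorophenyl in place of 2-hydroxyphenyl on the saturated chain carbon bound to a saturated ring carbon, stays within the scatter (a 1.1-fold lower number from compound 1 to compound 3 (0.04 log units; within the scatter)), so this assay does not separate those two aryl groups, and nothing available explains the size of either step.

As far as these compounds go, two groups on one aromatic carbon are too few to set a trend, so what a chlorine atom, a methoxy group or an amine would do at the same place remains open. Also open, from the compounds shown here alone, is whether the step from trifluoromethyl to fluoro would keep its size if the shared core carried a different group on its other benzyl arm.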